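Azole variation in a rat paw edema series

The source may hold more compounds than are shown below. What is called first, only, known or untested is meant among the compounds shown, and "the series" means these compounds.

Measured compounds in a functional assay on the whole organism for inhibition, with Rattus norvegicus as the target, read by paw edema; on this read-out higher numbers stand for an effect only at larger amounts of compound and lower numbers for an effect already at smaller amounts:
compound 1 `O=C(O)c1cc(-c2csnn2)ccc1O` — a limit only, > 200 mg/kg
compound 2 `O=C(O)c1cc(-n2ccnn2)ccc1O` — 150 mg/kg
compound 3 `O=C(O)c1cc(-c2ncc[nH]2)ccc1O` — 200 mg/kg

Compound 2 holds the lowest of the two numbers read; compound 3 sits nearest, with a 1.3-fold higher number from compound 2 to compound 3 (0.12 log units; within the scatter), which stays within the scatter. In this assay compound 1 gives only a limit (the limit of > 200 mg/kg in this assay, at which 1 of the 3 values shown sits), so the step of an at least 1.3-fold lower number from compound 1 to compound 2 (0.12 log units; that floor lies within the scatter) has only a floor. Compound 4 `O=C(O)c1cc(-c2cc[nH]n2)ccc1O` differs from compound 2 by 1H-pyrazol-3-yl in place of 1H-1,2,3-triazol-1-yl on an aromatic carbon. Among the compounds with values here, the one fully measured exchange of the five-membered ring starting from compound 2 stayed within the scatter, and the other is open in size; no step beyond the scatter is therefore expected in this assay in either direction. Compound 4 is estimated at 170 mg/kg, expected between 100 mg/kg and 300 mg/kg, meaning a step of a 1.1-fold higher number from compound 2 to compound 4 (0.05 log units; within the scatter).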

Compound 4, dose for half-maximal effect: > 250 mg/kg
Compound 4: only a limit was reported; the forecaster's own chance of this, stated with the estimate: 25%; middle value at least 1.4-fold (0.16 log units) from the limit.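

Compound 4 gives only a limit in this assay, so this exchange at the place para to the hydroxy group has no measured size: the limit of > 250 mg/kg in this assay, at which 1 of the 4 values shown sits.
Within the data shown here, the readable steps are floors, an at least 1.6-fold higher number from compound 2 to compound 4 (0.22 log units; that floor lies within the scatter) and an at least 1.2-fold higher number from compound 3 to compound 4 (0.09 log units; that floor lies within the scatter), so this is the first azole exchange from compound 2 with a floor this large, though it still does not clear the scatter. The step between compound 1 and compound 4 cannot be read.

From the compounds shown here alone, whether either step truly exceeds the scatter stays open. So does whether an amine or an amide at this place, instead of a five-membered aromatic ring, would give a clearly lower number.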